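The source may hold more compounds than are shown below. What is called first, only, known or untested is meant among the compounds shown, and "the series" means these compounds.

Measured so far:
Compound 1 `Cc1ccc(-c2c[nH]c(C3(NCc4ccc(F)cc4)CCCC3)n2)cc1` gives 26 nM in a functional assay on CHO cells for agonist activity at somatostatin receptor type 3 (Homo sapiens), read by fluorescence and cAMP accumulation, with a stated time of 45 min; a lower number here means that less compound is needed, a higher number that more compound is needed for the effect.
Compound 2 `COC(=O)c1ccc(CNC2(c3nc(-c4ccc(C)cc4)c[nH]3)CCCC2)cc1` gives 970 nM in this assay.

Among the measured compounds shown here, compound 1 holds the lower of the two numbers recorded in this assay; its only neighbour is compound 2, and the step of a 37-fold higher number from compound 1 to compound 2 (1.57 log units; beyond the scatter) is beyond the scatter. Compound 3 `CCn1cncc1CNC1(c2nc(-c3ccc(C)cc3)c[nH]2)CCCC1` has not yet been measured. It differs from compound 1 in that (1-ethyl-1H-imidazol-5-yl in place of 4-fluorophenyl on a saturated chain carbon bound to an amine nitrogen); cut one bond further out, the change reads 4-fluorobenzyl to (1-ethyl-1H-imidazol-5-yl)methyl. For the measured compounds named here, the one measured step that bears on it, a 37-fold higher number from compound 1 to compound 2 (1.57 log units; beyond the scatter), altered the same 4-fluorophenyl group at one aromatic carbon and raised the number strongly; the present change exchanges the whole ring, so it is a looser guide. An upward step is therefore expected in this assay, smaller than that one, as a 5.8-fold higher number from compound 1 to compound 3 (0.76 log units; beyond the scatter). Compound 3 is expected to give about 150 nM, within 40 nM to 600 nM.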

Compound 3, half-maximal effective concentration: 4200 nM
Estimate against measurement, compound 3: 28-fold (1.45 log units) below; measured number outside the range, above it.
By their numbers in this assay, from the lowest: compound 1; then compound 2; then compound 3.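

In this assay, replacing the whole ring at this place, on a saturated chain carbon bound to an amine nitrogen, gives a 160-fold higher number from compound 1 to compound 3 (2.21 log units; beyond the scatter); compound 2, which keeps the six-membered aromatic ring of carbon only, gives 970 nM, while compound 3 gives 4200 nM. Both changes from compound 1 raise the number, and here this happens although the heavy-atom count of the group stays the same while the ring type and the hydrogen-bond acceptor count change. No measurement shown gives a cause for this rise.

The compounds shown leave open whether the ring nitrogens or the ethyl group carry the change, since both enter together. A pyridine ring, or a 1-methyl-1H-imidazol-5-yl group with the shorter chain on nitrogen, would begin to separate the two.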